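A para-substituted phenyl in place of quinolinyl

The source may hold more compounds than are shown below. What is called first, only, known or untested is meant among the compounds shown, and "the series" means these compounds.

Measured compounds:
compound 1, `CCOC(=O)c1cnc(-c2ccccc2)nc1NN1C(=O)C=C(C)C1=O`: 100 nM
compound 2, `CCOC(=O)c1cnc(-c2cnc3ccccc3c2)nc1NN1C(=O)C=C(C)C1=O`: 6000 nM

Of the compounds shown here, two have been measured in a functional assay on Jurkat cells for inhibition of nuclear factor NF-kappa-B complex (Homo sapiens) (a lower number here means a stronger inhibitor, a higher number a weaker inhibitor), and they differ only in the aromatic group attached to the shared core. Compound 1 gives 100 nM, and compound 2 gives 6000 nM, the higher of the two numbers; the step of a 60-fold higher number from compound 1 to compound 2 (1.78 log units; beyond the scatter) lies beyond the scatter, so compound 2 is the weaker inhibitor of the pair.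

Compound 3, `CCOC(=O)c1cnc(-c2ccc(C(F)(F)F)cc2)nc1NN1C(=O)C=C(C)C1=O`, has not been measured. It differs from compound 2 as follows: 4-(trifluoromethyl)phenyl in place of quinolin-3-yl on an aromatic carbon. Going by the values given here, no measured pair shows exactly this change. Among the compounds with values here, the only step that bears on it is a 60-fold higher number from compound 1 to compound 2 (1.78 log units; beyond the scatter), which shows that quinolin-3-yl weakens inhibition relative to plain phenyl. Within the data shown here, compound 3 returns to a phenyl ring, now carrying a trifluoromethyl group, so its number is expected to fall back toward that of compound 1, though the added group has no measured precedent here. For compound 3 the estimated value in this assay is 400 nM, with a range from 80 nM to 3000 nM, which would mean an expected step of a 15-fold lower number from compound 2 to compound 3 (1.18 log units; beyond the scatter).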

Compound 3, half-maximal inhibitory concentration: 400 nM
Compound 3: the middle estimate sits on the measured number at the digits printed, and the stated range covers the measured number.
By their numbers in this assay, from the lowest: compound 1; then compound 3; then compound 2.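

Replacing quinolin-3-yl with 4-(trifluoromethyl)phenyl at this place on the shared core gives a 15-fold lower number from compound 2 to compound 3 (1.18 log units; beyond the scatter) in this assay and so recovers most of the loss seen with quinolin-3-yl, even though the new phenyl ring carries an added group. That added group still has a cost, with trifluoromethyl in place of hydrogen on the phenyl ring giving a 4.0-fold higher number from compound 1 to compound 3 (0.60 log units; beyond the scatter) and leaving the unsubstituted phenyl of compound 1 with the lowest number of the three. No supporting data are available to explain either change.

Going by these compounds, it remains open whether a methoxy group, a chlorine atom or an amine on the phenyl ring would bring the number closer to that of compound 1. A naphthyl group in place of quinolin-3-yl would be a useful further comparison with compound 2. It would keep the second ring and lack the ring nitrogen.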